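Isopropoxy to 2,4-difluorophenoxy on compound 1

The source may hold more compounds than are shown below. What is called first, only, known or untested is meant among the compounds shown, and "the series" means these compounds.

In a functional assay on MV4-11 cells (Homo sapiens) for antiproliferative activity, read by CCK-8 assay, with a stated time of 72 h (a higher number here means a weaker inhibitor, a lower number a stronger inhibitor), compound 1 `CC(C)Oc1ccc(C(C)(C)O)cc1-c1cn(C)c(=O)c2[nH]c(C(=O)NCCCCCCC(=O)NO)cc12` gives 160 nM as the lowest of three numbers. Compound 3 `CC(C)Oc1ccc(C(C)(C)O)cc1-c1cn(C)c(=O)c2[nH]c(C(=O)NCc3ccc(C(=O)NO)cc3)cc12` stands at 350 nM and compound 2 `Cn1cc(-c2cccc(C(C)(C)O)c2)c2cc(C(=O)NCc3ccc(C(=O)Nc4ccccc4N)cc3)[nH]c2c1=O` at 2200 nM in the same read-out. Compound 4 `Cn1cc(-c2cc(C(C)(C)O)ccc2Oc2ccc(F)cc2F)c2cc(C(=O)NCCCCCCC(=O)NO)[nH]c2c1=O` keeps the chain of compound 1 and carries 2,4-difluorophenyl in place of isopropyl on an oxygen on an aromatic ring in the ether, with 2,4-difluorophenyl in place of isopropyl on an oxygen on an aromatic ring. Among the measured compounds shown here, the only measured step of a 2.2-fold higher number from compound 1 to compound 3 (0.34 log units; beyond the scatter) is modest and alters the chain, not the ether, so it offers little guidance here. For the measured compounds named here, no measured pair varies this ether, so no step beyond the scatter is expected in this assay in either direction. The estimated step of a 1.1-fold lower number from compound 1 to compound 4 (0.03 log units; within the scatter) is accordingly small. Compound 4 is expected at 150 nM with an estimated range from 50 nM to 450 nM in this read-out.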

Compound 4, half-maximal inhibitory concentration: 250 nM
Compound 4: middle estimate off by 1.7-fold (0.22 log units), on the low side; the measured number falls inside the stated range.
By their numbers in this assay, from the lowest: compounds 1, 4 and 3 (each within the scatter of the next, the first and the last beyond it); then compound 2.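

In this assay the ether position of compound 1 takes 2,4-difluorophenyl in place of isopropyl, with a 1.6-fold higher number from compound 1 to compound 4 (0.19 log units; within the scatter) as the step, so eight heavy atoms and an aromatic ring enter on the oxygen without a shift beyond the scatter. Among the compounds shown here, this is the first measured change at this position, and it holds for the chain of compound 1 only. Nothing available bears on why the number holds. As far as these compounds go, whether the same exchange holds with the 4-(hydroxycarbamoyl)phenyl of compound 3 remains open. Also open, from the compounds shown here alone, is how an amine or a carboxylic acid on this oxygen substituent would read.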